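This account rests on a few compounds, and the source may have more. Where it says the series, first, only, none or still open, it means among the compounds named here.

Measured so far in an ADME assay on BCBL1 cells (Homo sapiens) for cytotoxicity, with a stated time of 7 days; on this read-out lower numbers stand for higher toxicity in this test and higher numbers for lower toxicity in this test:
- Compound 1 `CC(C)CNc1nc(N)nc2c1ncn2/C=C1/CC1(CO)CO`: > 20000 nM
- Compound 2 `CCCOc1nc(N)nc2c1ncn2/C=C1/CC1(CO)CO`: > 20000 nM

Compound 2 gives > 20000 nM, which is a limit of this assay and not a number. The record so far is the limit of > 20000 nM in this assay, at which 2 of the 2 values shown sit. Compound 3 `CCCCOc1nc(N)nc2c1ncn2/C=C1/CC1(CO)CO` differs from compound 2 by a single change: methyl in place of hydrogen on a saturated chain carbon, three bonds along the chain from an oxygen on an aromatic ring. This turns propyl to butyl. Among the compounds with values here, the only measured step is a step that the two limits leave unreadable from compound 1 to compound 2. Within the data shown here, it gives no size to carry over, and no measured step tests the new change. No step beyond the usual scatter is therefore expected in this assay, although a shift toward higher toxicity remains possible. Compound 3 will most likely be reported as a limit too. The expected change is a number no higher from compound 2 to compound 3 (the limit leaves the size open). The estimate for compound 3 is 20000 nM, with an expected range from 9000 nM to 20000 nM.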

Compound 3, half-maximal cytotoxic concentration: > 20000 nM
Compound 3 was reported as a limit; the forecaster's own chance of this, stated with the estimate: 70%; the middle value sits exactly at the limit.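

Within the data shown here, neither the step from compound 2 to compound 3 nor the one from compound 1 to compound 3 can be read in this assay, as all three results are limits and not numbers: the limit of > 20000 nM in this assay, at which 3 of the 3 values shown sit. The compounds shown leave open whether propyl to butyl changes toxicity in this test at all.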